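The source may report more compounds than this note shows. Statements on the series, on what has been measured and on what is new or still open speak of the compounds shown alone.

Measured so far in an ADME assay on microsomes from liver (Homo sapiens) for metabolic stability, with a stated time of 30 min; on this read-out higher numbers stand for a more stable compound and lower numbers for a less stable compound:
compound 1 `CCCCc1nc(C)c(CC(=O)OCC)c(=O)n1Cc1ccc(-c2ccccc2-c2noc(=O)[nH]2)cc1` gives 46.6%; 46.5% (2 entries)
compound 2 `CCCCc1nc(C)c(CC(=O)OC)c(=O)n1Cc1ccc(-c2ccccc2-c2noc(=O)[nH]2)cc1` gives 69.6%
compound 3 `CCCCOC(=O)Cc1c(C)nc(CCCC)n(Cc2ccc(-c3ccccc3-c3noc(=O)[nH]3)cc2)c1=O` gives 2.8%

Compound 3 stands lowest of the two single numbers in this assay; the nearest is compound 2, and the step of a number 66.8 percentage points lower from compound 2 to compound 3 (beyond the scatter) is large and beyond the scatter. The two entries of compound 1, (the several entries of compound 1 in this assay, 46.6%; 46.5% (2 entries)), show how closely a repeat of this assay agrees with itself.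

Compound 4 `CCCCc1nc(C)c(CC(=O)OCC(C)C)c(=O)n1Cc1ccc(-c2ccccc2-c2noc(=O)[nH]2)cc1` differs from compound 3 by isopropyl in place of propyl on a saturated chain carbon bound to an oxygen next to a carbonyl group. Among the compounds with values here, the only measured step on this part of the molecule is a number 66.8 percentage points lower from compound 2 to compound 3 (beyond the scatter), which added three carbons to the chain; the step to compound 4 keeps the carbon count and only rearranges it, so no measured step covers it directly. The expectation for compound 4 therefore stays near compound 3, with a small upward step a number 7.2 percentage points higher from compound 3 to compound 4 (within the scatter) that may lie within the scatter, resting on compound 3 giving 2.8%. Compound 4 is estimated at 10%, ranging from 2% to 30%.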

Compound 4, percent of the compound remaining: 2.4%
Beside the measured number, compound 4's estimate is 7.6 percentage points above it, and the stated range covers the measured number.
By their numbers in this assay, from the lowest: compounds 4 and 3 (each within the scatter of the next); then compound 2.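

In this assay, rearranging the ester chain leaves no readable difference: isopropyl in place of propyl on a saturated chain carbon bound to an oxygen next to a carbonyl group gives a number 0.4 percentage points lower from compound 3 to compound 4 (within the scatter). The large loss seen with the butyl ester is therefore not confined to the unbranched chain, since the isobutyl ester shows it too, with a number 67.2 percentage points lower from compound 2 to compound 4 (beyond the scatter). Repeats in this assay agree closely, which supports reading compound 3 and compound 4 as one low level: the several entries of compound 1 in this assay, 46.6%; 46.5% (2 entries).

The compounds shown leave open whether an isopropyl ester, a tert-butyl ester or an amide in place of the ester would keep a value near that of compound 2. They also do not show how a carboxylic acid at this place would behave on this read-out.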